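The compounds below may be only part of what the source reports. "The series", "measured", "known", "first", "only" and "open" are said of these compounds alone.

Values from a functional assay on CNE2Z cells (Homo sapiens) for inhibition, read by MTT assay, with a stated time of 72 h (a higher number here means a weaker inhibitor, a lower number a stronger inhibitor), are as follows
- Compound 1 `C=CCc1ccc(OCc2c(Cl)cccc2Cl)c(-c2ccc(OCc3c(Cl)cccc3Cl)c(CC=C)c2)c1` gives > 50000 nM as a limit
- Compound 2 `C=CCc1ccc(O)c(-c2ccc(OCc3ccccc3)c(CC=C)c2)c1` gives 30300 nM as a number
- Compound 3 `C=CCc1ccc(OCc2c(Cl)cccc2Cl)c(-c2ccc(O)c(CC=C)c2)c1` gives 19900 nM as a number

Compound 2 at 30300 nM carries benzyl and compound 3 at 19900 nM carries 2,6-dichlorobenzyl, yet the two lie within the scatter of each other. Compound 4 `C=CCc1ccc(O)c(-c2ccc(OCc3ccc(Cl)cc3Cl)c(CC=C)c2)c1` has 2,4-dichlorophenyl in place of the phenyl of compound 2, on a saturated chain carbon bound to an oxygen on an aromatic ring (2,4-dichlorophenyl in place of phenyl on a saturated chain carbon bound to an oxygen on an aromatic ring). Going by the values given here, the one measured step, an at least 2.5-fold lower number from compound 1 to compound 3 (0.40 log units; beyond the scatter), removes a whole 2,6-dichlorobenzyl, so it bears only loosely on this change. No shift beyond the scatter is therefore expected in this assay here. The expected change is a 1.5-fold lower number from compound 2 to compound 4 (0.18 log units; within the scatter) overall. For compound 4 the estimated value is 20000 nM within an expected range of 8000 nM to 50000 nM in this assay.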

Compound 4, half-maximal inhibitory concentration: 11300 nM
The estimate for compound 4 lay 1.8-fold (0.25 log units) above the measured number; measured number inside the range.
By their numbers in this assay, from the lowest: compounds 4, 3 and 2 (each within the scatter of the next, the first and the last beyond it). At a limit, above all of these: compound 1.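

In this assay, the change from benzyl to 2,4-dichlorobenzyl gives a 2.7-fold lower number from compound 2 to compound 4 (0.43 log units; beyond the scatter). This is the first listed step that alters only the ring of this group rather than removing the whole group, and it shows that the ring's substituents alone can move the number by a modest amount. Nothing available here explains the shift.

On these data alone, it remains open whether one chlorine alone would give the same shift. Also open, as far as these compounds go, is how a benzyl ring carrying an amine or a carboxylic acid instead would behave.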